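Dimethoxyphenyl for Dihalophenyl on the Oxazole-Like Core

The source may report more compounds than this note shows. Statements on the series, on what has been measured and on what is new or still open speak of the compounds shown alone.

The measured compounds:
Compound 1 `Cc1ccccc1-c1nc(CN2CCC(C(=O)NCCCN3CCC(C(C)C)CC3)CC2)c(C)o1` gives 0.147 h in an ADME assay on microsomes from liver (Rattus norvegicus) for metabolic stability, read by LC-MS, using NADPH, at 37 degrees C; on this read-out lower numbers stand for a shorter-lived compound and higher numbers for a longer-lived compound.
Compound 2 `CC[C@@H]1C[C@H](CC)CN(CCCNC(=O)C2CCN(Cc3nc(-c4c(F)cccc4F)oc3C)CC2)C1` gives 0.065 h in this assay.
Compound 3 `Cc1oc(-c2c(Cl)cccc2Br)nc1CN1CCC(C(=O)NCCCN2C[C@H](C)C[C@H](C)C2)CC1` gives 0.0233 h in this assay.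

Among these three, compound 3 has the lowest number, and its gaps to compound 2 and to compound 1 both lie beyond the usual scatter of repeated measurements, so it is the shortest-lived of the set. No two of the measured compounds differ in only one place, so the three values are read side by side without any single change being isolated.

Compound 4 `COc1cccc(OC)c1-c1nc(CN2CCC(C(=O)NCCCN3C[C@H](C)C[C@H](C)C3)CC2)c(C)o1` differs from compound 3 in one place: 2,6-dimethoxyphenyl in place of 2-bromo-6-chlorophenyl on an aromatic carbon

Going by the values given here, with no measured pair that isolates this kind of change, the step is judged from the spread of the three numbers alone. The expectation is a modest rise from compound 3 to compound 4 in this assay, a step of a 1.7-fold higher number from compound 3 to compound 4 (0.23 log units; within the scatter) that may well fall within the scatter. Compound 4 is estimated at 0.04 h, with a range from 0.012 h to 0.13 h.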

Compound 4, half-life: 0.2 h
Compound 4: the middle estimate sits 5.0-fold (0.70 log units) below what was measured; the whole stated range lies below it.
By their numbers in this assay, from the lowest: compound 3; then compound 2; then compounds 1 and 4 (each within the scatter of the next).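

With the rest of compound 3 held fixed, the group on this aromatic carbon of the five-membered ring proves to matter in this assay: an 8.6-fold higher number from compound 3 to compound 4 (0.93 log units; beyond the scatter) is a rise beyond the scatter, toward a longer-lived compound. Going by these compounds alone, this is the first step in the set that isolates one change, and it swaps 2-bromo-6-chlorophenyl for 2,6-dimethoxyphenyl while keeping the same six-membered aromatic carbon ring, adding two hydrogen-bond acceptors and two heavy atoms. No measurement at hand bears on what lies behind the rise.

The compounds shown leave open whether a single methoxy group, an ethoxy group or a pyridine ring in place of the phenyl would give a similar rise. They also leave open whether the same swap would act alike on the amine ends of compound 1 and compound 2.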